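The source may hold more compounds than are shown below. What is called first, only, known or untested is meant among the compounds shown, and "the series" means these compounds.

Of the compounds shown here, two have been measured so far in a functional assay on NCI-H460 cells (Homo sapiens) for cytotoxicity, read by MTT assay, with a stated time of 96 h (on this read-out higher numbers stand for weaker inhibition and lower numbers for stronger inhibition), and they read as follows.
Compound 1 `COc1ncc(-c2cc(OCC3CC3)c3nc(N)nc(C)c3c2)cc1NS(=O)(=O)c1ccc(F)cc1F` gives 200 nM
Compound 2 `COc1ncc(-c2cc(OCC3CCOCC3)c3nc(N)nc(C)c3c2)cc1NS(=O)(=O)c1ccc(F)cc1F` gives 21 nM

Compound 2 stands lower of the two, at 21 nM on this read-out. Compound 3 `CNc1nc(C)c2cc(-c3cnc(OC)c(NS(=O)(=O)c4ccc(F)cc4F)c3)cc(OCC3CCOCC3)c2n1` differs from compound 2 by methyl in place of hydrogen on a nitrogen on an aromatic ring and so carries methyl in place of hydrogen on a nitrogen on an aromatic ring. Among the compounds with values here, the only measured step is a 9.5-fold lower number from compound 1 to compound 2 (0.98 log units; beyond the scatter) and it lies elsewhere, with oxan-4-yl in place of cyclopropyl on a saturated chain carbon bound to an oxygen on an aromatic ring. Within the data shown here, no measured step touches that nitrogen, so this one offers only a rough scale. A smaller step is therefore expected in this assay and the direction, toward a higher number, is a tentative expectation. The estimated change is a 2.9-fold higher number from compound 2 to compound 3 (0.46 log units; beyond the scatter) and no more than that. For compound 3 the expected value is 60 nM with an estimated range from 15 nM to 300 nM in this assay.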

Compound 3, half-maximal inhibitory concentration: 400 nM
The estimate for compound 3 lay 6.7-fold (0.82 log units) below the measured number; measured number above the stated range.
By their numbers in this assay, from the lowest: compound 2; then compounds 1 and 3 (each within the scatter of the next).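

In this assay, methyl in place of hydrogen on a nitrogen on an aromatic ring gives a 19-fold higher number from compound 2 to compound 3 (1.28 log units; beyond the scatter), so a change of only one carbon at this position is enough to produce a large step in the unfavourable direction. The earlier pair varied only the group on the saturated chain carbon and kept the amino group unchanged, so it could not show that this nitrogen matters for the read-out. Nothing available explains why the methylamino group costs so much here.

The compounds shown leave open whether a larger group on this nitrogen, such as ethylamino or dimethylamino, would move the number further or no further. They also leave open whether the amino to methylamino change would have the same size with cyclopropyl in place of oxan-4-yl.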